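The source may report more compounds than this note shows. Statements on the series, on what has been measured and on what is new or still open speak of the compounds shown alone.

Of the compounds shown here, three built on one shared core have been tested in a functional assay on SK-MEL-5 cells (Homo sapiens) for cytotoxicity, read by sulforhodamine B assay, with a stated time of 48 h; a lower number here means a stronger inhibitor of growth, a higher number a weaker inhibitor of growth. Compound 1 `ClCc1cccc(Cn2cnc3ncnc(Cl)c32)c1` gives 18200 nM. Compound 3 `ClCc1cccc(Cn2cnc3nc(Cl)nc(Cl)c32)c1` differs from it by a single added group: chloro in place of hydrogen on an aromatic carbon. In this assay compound 3 gives 2450 nM. That addition lowered the number, a 7.4-fold lower number from compound 1 to compound 3 (0.87 log units; beyond the scatter). Compound 2 `ClCc1ccccc1Cn1cnc2ncnc(Cl)c21` contains the same atoms as compound 1, joined differently; the difference between the two cores is not broken down here. In this assay compound 2 gives 4070 nM. Its nearest neighbour among the measured compounds is compound 3, and the gap between them lies within the usual scatter, so no order can be read between those two; compound 1, by contrast, stands clearly higher than compound 2.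

Compound 4 `ClCc1ccccc1Cn1cnc2nc(Cl)nc(Cl)c21` has not been measured. It stands to compound 2 exactly as compound 3 stands to compound 1: chloro in place of hydrogen on an aromatic carbon. The place of the change is described in the same words for both pairs, so this is the same change, now made on the core of compound 2. Among the measured compounds shown here, only one measured example of the change exists. The step from compound 2 to compound 4 is therefore expected to run in the same direction but is estimated a little more cautiously, a 5.8-fold lower number from compound 2 to compound 4 (0.76 log units; beyond the scatter), resting on the measured step of a 7.4-fold lower number from compound 1 to compound 3 (0.87 log units; beyond the scatter). Compound 4 is expected to give about 700 nM in this assay, most likely between 300 nM and 2000 nM.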

Compound 4, concentration for total growth inhibition: 2180 nM
The estimate for compound 4 lay 3.1-fold (0.49 log units) below the measured number, and the stated range ends below it.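

On the core of compound 2, chloro in place of hydrogen on an aromatic carbon gives a 1.9-fold lower number from compound 2 to compound 4 (0.27 log units; within the scatter) in this assay and so no order can be read between these two compounds. The same change therefore does not carry over from one core to the other at a fixed size, and the two steps differ by more than repeated measurements would explain: the same change on two cores in this assay, a 7.4-fold lower number (0.87 log units; beyond the scatter) from compound 1 to compound 3 and a 1.9-fold lower number (0.27 log units; within the scatter) from compound 2 to compound 4, 4.0-fold (0.60 log units) apart, beyond the scatter of two such steps. This shows that the size of the step on the core of compound 1 is a poor guide to its size on the core of compound 2, but it does not show why the two cores differ, and two pairs cannot say what the change would do on any further core.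

The compounds shown carry only hydrogen or chloro on this aromatic carbon, so it remains open how an amine, a methoxy group or a fluoro group would read there. As far as these compounds go, it also remains open how a hydroxymethyl group or a longer chain would compare with the chloromethyl group on either core.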